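Two Chromone Analogues and a Trimmed Side Chain

The source may hold more compounds than are shown below. What is called first, only, known or untested is meant among the compounds shown, and "the series" means these compounds.

Measured so far:
- compound 1, `Cc1cc(=O)c2c(O)cc(OC/C=C/c3ccccc3)c([C@H]3CCN(C)C[C@H]3O)c2o1`, 18%
- compound 2, `Cc1cc(=O)c2c(O)c(CN3CCC(N4CCCCC4)CC3)c(O)c([C@H]3CCN(C)C[C@H]3O)c2o1`, 17%

Both compounds were tested in a functional assay on PC-3 cells (Homo sapiens) for inhibition, read by MTT assay, with a stated time of 48 h, tested at 10 uM; a higher number here means more inhibition of growth at the concentration tested, a lower number less inhibition of growth. Compound 1 gives 18%. Compound 2 gives 17%, the lower of the two numbers, though its distance to compound 1 is within the scatter, so the two cannot be told apart on these data.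

The next compound, compound 3, `Cc1cc(=O)c2c(O)c(CN3CCCCC3)c(O)c([C@H]3CCN(C)C[C@H]3O)c2o1`, differs from compound 2 in one place: hydrogen in place of piperidin-1-yl on a saturated ring carbon. Among the measured compounds shown here, no step between two measured compounds of this kind has been recorded, so there is nothing to anchor a prediction of direction or size. Given that the two measured values sit close together, the step expected in this assay is none beyond the scatter.

For compound 3 the estimated value is 17%, within a range from 5% to 32%, which is expected to amount to no change at the digits printed from compound 2 to compound 3 (within the scatter).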

Compound 3, percent growth inhibition at one concentration: 14%
Compound 3: the middle estimate sits 3 percentage points above what was measured, within the range that was stated.
By their numbers in this assay, from the lowest: compounds 3, 2 and 1 (each within the scatter of the next).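

Among the compounds shown here, this is the first step that can be read at this place, on a saturated ring carbon three ring bonds from the ring nitrogen. In this assay the step is a number 3 percentage points lower from compound 2 to compound 3 (within the scatter) and so removing the piperidin-1-yl, a group of 6 heavy atoms with its own ring, leaves a number that cannot be told apart from that of compound 2. No measurement at hand bears on why this group makes so little visible difference.

Going by these compounds, whether a different group on the same carbon, such as a primary amine, a carboxylic acid or a longer chain like n-butyl, would give a step beyond the scatter remains open. A single concentration also leaves open whether compound 2 and compound 3 would still match at other concentrations.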